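This account rests on a few compounds, and the source may have more. Where it says the series, first, only, none or still open, it means among the compounds named here.

Series notes. Compound 2 `CC(C)=CCC/C(C)=C/CC/C(C)=C/CSC[C@H](NC(=O)CCCCCN1CCN(C)CC1)C(=O)NC1CCCCCCC1` gives 5.88 in a physicochemical assay for lipophilicity; a higher number here means a more lipophilic compound, a lower number a more polar compound. Compound 1 `CC(C)=CCC/C(C)=C/CC/C(C)=C/CSC[C@H](NC(=O)CCCCCN1CCN(C)CC1)C(=O)NC1CC1` gives 3.66 in this assay; the step of a number 2.22 log units lower from compound 2 to compound 1 (beyond the scatter) goes with the change (cyclopropyl in place of cyclooctyl on an amide-type nitrogen). Compound 3 `CC(C)=CCC/C(C)=C/CC/C(C)=C/CSC[C@H](NC(=O)CCCCCN1CCCC1)C(=O)NC1CCCCCCC1` gives 5.37 in this assay; its core differs from the core of compound 2 by pyrrolidin-1-yl in place of 4-methylpiperazin-1-yl on a saturated chain carbon, five bonds along the chain from a carbonyl carbon, with the step of a number 0.51 log units lower from compound 2 to compound 3 (beyond the scatter). Compound 4 `CC(C)=CCC/C(C)=C/CC/C(C)=C/CSC[C@H](NC(=O)CCCCCN1CCCC1)C(=O)NC1CC1` is not yet measured in this assay; it differs from compound 3 by cyclopropyl in place of cyclooctyl on an amide-type nitrogen, the same change as from compound 2 to compound 1, made in the same place. For the measured compounds named here, the step from compound 3 to compound 4 is expected to be a number 2.22 log units lower from compound 3 to compound 4 (beyond the scatter), because a number 2.22 log units lower from compound 2 to compound 1 (beyond the scatter) is the one earlier instance of this change. Compound 4 is therefore estimated at 3.15, with a range from 2.7 to 3.6. The two instances sit on different cores, which is the main uncertainty.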

Compound 4, distribution coefficient: 3.15
The estimate for compound 4 equals the measured number at the digits printed, and the stated range covers the measured number.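

In this assay cyclopropyl in place of cyclooctyl on an amide-type nitrogen gives a number 2.22 log units lower from compound 3 to compound 4 (beyond the scatter) and, on the other core, a number 2.22 log units lower from compound 2 to compound 1 (beyond the scatter) at the same size, while pyrrolidin-1-yl in place of 4-methylpiperazin-1-yl gives a number 0.51 log units lower from compound 1 to compound 4 (beyond the scatter) and a number 0.51 log units lower from compound 2 to compound 3 (beyond the scatter) at the same size. Across these four compounds the two changes therefore add without any measured interplay, but this rests on a single pair of cores and does not show that the step carries to any other core. No supporting data bear on what sets the size of either step.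

Open, on these data alone, is whether a cyclohexyl or a phenyl group on that nitrogen falls on the same line. Also open, as far as these compounds go, is whether the step keeps its size on a core with morpholin-4-yl in place of the pyrrolidin-1-yl.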